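Replacing the piperidinyl group of compound 3 by a fluorinated ether

A few compounds are considered here, and "the series" means these few. Any claim that something is new, unique, unknown or untested is made for them only; others in the source may bear on it.

Of the compounds shown here, three share one core and have been tested in a physicochemical assay for solubility, in simulated intestinal fluid; a lower number here means a less soluble compound, a higher number a more soluble compound. Compound 1 `COc1ccccc1C(=O)NC(=O)Nc1ccc(N2CCCCC2)c(Cl)c1` gives 8.5 ug/mL, compound 2 `COc1ccccc1C(=O)NC(=O)Nc1ccc(-c2ccccn2)c(C(F)(F)F)c1` gives 8.5 ug/mL, and compound 3 `COc1ccccc1C(=O)NC(=O)Nc1ccc(N2CCCCC2)c(C(F)(F)F)c1` gives 4.1 ug/mL. Compound 3 thus has the lowest number of the three: the change a 2.1-fold lower number from compound 1 to compound 3 (0.32 log units; beyond the scatter) and the change a 2.1-fold lower number from compound 2 to compound 3 (0.32 log units; beyond the scatter) both end at it, each of modest size and beyond the scatter.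

Compound 4 `COc1ccccc1C(=O)NC(=O)Nc1ccc(OCC(F)(F)F)c(C(F)(F)F)c1` differs from compound 3 in one place: 2,2,2-trifluoroethoxy in place of piperidin-1-yl on an aromatic carbon. Among the compounds with values here, no measured step introduces a 2,2,2-trifluoroethoxy group, so neither step bears directly on this change. Within the data shown here, the only step that touches the piperidin-1-yl group, a 2.1-fold lower number from compound 2 to compound 3 (0.32 log units; beyond the scatter), runs the other way, with a modest fall in this assay when that group enters in place of pyridin-2-yl. On that basis a modest rise, or no step beyond the scatter, is expected for the change a 1.7-fold higher number from compound 3 to compound 4 (0.23 log units; within the scatter) in this assay. Compound 4 is therefore estimated at 7 ug/mL, with a range from 3 ug/mL to 18 ug/mL.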

Compound 4, solubility: 2.2 ug/mL
Beside the measured number, compound 4's estimate is 3.2-fold (0.50 log units) above it; the whole stated range lies above it.
By their numbers in this assay, from the lowest: compounds 4 and 3 (each within the scatter of the next); then compounds 1 and 2 (each within the scatter of the next).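

In this assay the step of a 1.9-fold lower number from compound 3 to compound 4 (0.27 log units; within the scatter) shows that, at this position ortho to a trifluoromethyl group, 2,2,2-trifluoroethoxy cannot be told apart from piperidin-1-yl, although the first has no ring and the second has a six-membered non-aromatic ring. The step of a 3.9-fold lower number from compound 2 to compound 4 (0.59 log units; beyond the scatter) does lie beyond the scatter, so with trifluoromethyl kept, pyridin-2-yl stands apart from 2,2,2-trifluoroethoxy, just as the step of a 2.1-fold lower number from compound 2 to compound 3 (0.32 log units; beyond the scatter) sets it apart from piperidin-1-yl. Nothing measured here accounts for these results.

The compounds shown leave open whether 2,2,2-trifluoroethoxy would give the same picture with chloro in place of trifluoromethyl. They also leave open how a morpholine ring, a primary amine or a carboxylic acid at this position would compare with the pyridin-2-yl group of compound 2 in this assay on the same core.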